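Working notes on growth inhibition in a small allyl-phenol series

The compounds below may be only part of what the source reports. "The series", "measured", "known", "first", "only" and "open" are said of these compounds alone.

Measured so far:
compound 1, `C=CCc1ccc(OCc2cn(-c3ccccc3CO)nn2)c(O)c1`, 87.1%
compound 2, `C#CCOc1ccc(CC=C)cc1O`, 88.4%
compound 3, `C=CCc1cc(O)c(O)c(CN2CCC(Cc3ccccc3)CC2)c1`, 83.4%

In a functional assay on SK-N-SH cells (Homo sapiens) for inhibition, read by MTT assay, with a stated time of 72 h, tested at 50 uM (a higher number here means more inhibition of growth at the concentration tested, a lower number less inhibition of growth), compound 1 gives 87.1%, the second highest of the three numbers. Compound 2 gives 88.4% and compound 3 gives 83.4%; both sit within the scatter of compound 1, so the three cannot be ordered. Among the measured compounds shown here, no pair of measured compounds differs in one place, so no single-point step is known.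

Compound 4, `C=CCc1ccc(OCc2cn(-c3ccc(Br)cc3)nn2)c(O)c1`, differs from compound 1 by 4-bromophenyl in place of 2-(hydroxymethyl)phenyl on an aromatic nitrogen. With all three measured numbers lying close together at this concentration, no shift beyond the scatter is expected. Compound 4 is estimated at 85%, between 72% and 95%. The expected step of a number 2.1 percentage points lower from compound 1 to compound 4 (within the scatter) lies within the scatter.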

Compound 4, percent growth inhibition at one concentration: 61.7%
Estimate against measurement, compound 4: 23.3 percentage points above, and the stated range ends above it.
By their numbers in this assay, from the lowest: compound 4; then compounds 3, 1 and 2 (each within the scatter of the next).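

The group on the aromatic nitrogen matters at this concentration: 4-bromophenyl in place of 2-(hydroxymethyl)phenyl gives a number 25.4 percentage points lower from compound 1 to compound 4 (beyond the scatter), the first single-place step known in the series. The change removes the hydroxymethyl group and its hydrogen-bond donor and acceptor, adds bromine, and moves the substituent on the phenyl ring, so this one step cannot separate these features. No measurement at hand gives a reason for the step.

Which of these features carries the step remains open. A plain phenyl on the same nitrogen, or a phenyl bearing a carboxylic acid, would give further points at this position.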